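Two More Fluorines on the Sulfonyl-Bound Ring

The source may hold more compounds than are shown below. What is called first, only, known or untested is meant among the compounds shown, and "the series" means these compounds.

The shared core carries a sulfonyl group whose aryl ring is varied. Compound 1 `COc1ccc(-c2cc(=O)c3c(OC)cc(OC)cc3n2S(=O)(=O)c2ccc(C#N)cc2)cc1` carries a cyanophenyl ring there, and in a functional assay on SEM cells (Homo sapiens) for antiproliferative activity, with a stated time of 72 h (on this read-out lower numbers stand for an effect already at smaller amounts and higher numbers for an effect only at larger amounts of compound), compound 1 gives 1300 nM. Among the measured compounds shown here, compound 2 `COc1ccc(-c2cc(=O)c3c(OC)cc(OC)cc3n2S(=O)(=O)c2cc(F)c(F)c(F)c2)cc1` carries a 3,4,5-trifluorophenyl ring in the same place; in this assay compound 2 gives "not determined" (no result reported), so no number anchors it and the only measured point is compound 1. Compound 3 `COc1ccc(-c2cc(=O)c3c(OC)cc(OC)cc3n2S(=O)(=O)c2c(F)c(F)c(F)c(F)c2F)cc1` differs from compound 2 in one respect: 2,3,4,5,6-pentafluorophenyl in place of 3,4,5-trifluorophenyl on a sulfonyl sulfur. Two further fluorine atoms join an already fluorinated ring, while the rest of the molecule is unchanged. For the measured compounds named here, no measured pair here shows what such a change does, so the expectation is simply that compound 3 lands near the measured neighbourhood, with any shift from compound 2 likely to stay within the usual scatter. Compound 3 is therefore estimated at 1500 nM, within a range of 300 nM to 8000 nM.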

Compound 3, half-maximal effective concentration: 3900 nM
The estimate for compound 3 lay 2.6-fold (0.41 log units) below the measured number, within the range that was stated.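

In this assay, putting 2,3,4,5,6-pentafluorophenyl in place of 4-cyanophenyl on the sulfonyl sulfur gives a 3.0-fold higher number from compound 1 to compound 3 (0.48 log units; beyond the scatter). This modest step lies beyond the usual scatter, so the ring at this position does affect the read-out, and of these two rings the 4-cyanophenyl one gives the lower number. Going by these compounds, compound 2 has no number, so the steps that involve it cannot be read, and what the two added fluorines do on their own stays unknown.

Nothing available here explains the shift between the two measured compounds. On these data alone, it also remains open whether a phenyl ring carrying an amine or a carboxylic acid in place of these substituents would lower or raise the number at this position.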